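Thiazoleacetic acids for prostaglandin D2 receptor 2: aryl swap

The source may hold more compounds than are shown below. What is called first, only, known or untested is meant among the compounds shown, and "the series" means these compounds.

Measured so far:
compound 1, `Nc1nc(-c2ccc(Cl)cc2)c(CC(=O)O)s1`, > 100000 nM
compound 2, `O=C(O)Cc1sc(C(c2ccc(F)cc2)c2ccc(F)cc2)nc1-c1ccnc(F)c1`, 0.48 nM
compound 3, `O=C(O)Cc1sc(C(c2ccccc2)c2ccccc2)nc1-c1ccc(C(F)(F)F)cc1`, 1100 nM

In an in vitro assay on HEK385-7 cells for displacement of a labelled ligand from prostaglandin D2 receptor 2 (Homo sapiens) (on this read-out higher numbers stand for weaker inhibition and lower numbers for stronger inhibition), compound 1 gives only a limit, > 100000 nM, and not a number; this is the limit of > 100000 nM in this assay, at which 1 of the 3 values shown sits. Going by the values given here, of the two numbers in this assay, compound 2 holds the lower one, 0.48 nM, and compound 3 the higher one, 1100 nM; no single-point step connects these two, since they differ at more than one place, so only the two values themselves can be compared, and they lie well apart.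

The next compound, compound 4, `O=C(O)Cc1sc(C(c2ccc(F)cc2)c2ccc(F)cc2)nc1-c1ccoc1`, is compound 2 with one change: furan-3-yl in place of 2-fluoropyridin-4-yl on an aromatic carbon

Both rings that change carry the same count of hydrogen-bond acceptors, but the entering ring is smaller and five-membered. Among the compounds with values here, no measured pair in this set isolates such a swap, so the size of the step cannot be read from the data; a moderate rise in the number, beyond the scatter but well short of the gap between compound 2 and compound 3, is expected. The estimate for compound 4 in this assay is 3 nM, within 0.5 nM to 30 nM, which means an expected step of a 6.3-fold higher number from compound 2 to compound 4 (0.80 log units; beyond the scatter).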

Compound 4, half-maximal inhibitory concentration: 14 nM
Compound 4: the middle estimate sits 4.7-fold (0.67 log units) below what was measured; the range from low to high includes it.
By their numbers in this assay, from the lowest: compound 2; then compound 4; then compound 3. At a limit, above all of these: compound 1.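

In this assay, going by these compounds alone, replacing 2-fluoropyridin-4-yl with furan-3-yl gives a 29-fold higher number from compound 2 to compound 4 (1.46 log units; beyond the scatter), the first single-place step, and it shows that the aromatic carbon next to the ring nitrogen is sensitive to the ring it carries. Both rings have the same count of hydrogen-bond acceptors and one hetero atom each, so keeping those counts does not keep the number at this place, although compound 4, at 14 nM, shows that a five-membered aromatic ring still gives a low number here rather than a limit. Within the data shown here, nothing measured so far gives a reason for the size of this step.

Among these compounds, the swap changes ring size, the hetero atom and the fluorine all at once, so their shares in the step remain unseparated, and compounds 1 and 3 differ from compounds 2 and 4 at more than one place and add no step to this question. A pyridin-4-yl ring without the fluorine would isolate the fluorine's share, while a thiophen-3-yl ring would test sulfur in place of the furan oxygen at the same carbon.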